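Shifting One Hydroxyl Group: From Compound 2 to Compound 3

The source may report more compounds than this note shows. Statements on the series, on what has been measured and on what is new or still open speak of the compounds shown alone.

Two measured compounds share a core and were examined in a functional assay on HeLa cells (Homo sapiens) for cytotoxicity, read by CCK-8 assay; on this read-out lower numbers stand for stronger inhibition and higher numbers for weaker inhibition. Compound 1 `Oc1ccc(-c2cc(-c3cccs3)cc(-c3ccccc3O)n2)cc1` gives > 50000 nM in this assay, which is a limit of the assay rather than a number. Compound 2 `Oc1cccc(-c2cc(-c3ccco3)cc(-c3ccccc3O)n2)c1` gives > 50000 nM in this assay, again a limit and not a number. Compound 2 therefore stands exactly where the other measured value also sits, as shown by the limit of > 50000 nM in this assay, at which 2 of the 2 values shown sit, and no difference between compound 1 and compound 2 can be read from these two limits. Compound 3 `Oc1ccc(-c2cc(-c3ccco3)cc(-c3ccccc3O)n2)cc1` has not yet been measured. It differs from compound 2 by 4-hydroxyphenyl in place of 3-hydroxyphenyl on an aromatic carbon, the two structures having the same atoms joined differently. For the measured compounds named here, no measured step with a number is available to guide the expectation. The expected step is a step that the limit leaves unreadable from compound 2 to compound 3, nothing beyond the usual scatter, with compound 3 most likely remaining at the limit. For compound 3 in this assay the estimated value is 70000 nM, with a range from 30000 nM to 200000 nM.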

Compound 3, half-maximal inhibitory concentration: > 50000 nM
Compound 3 was reported as a limit; the forecaster's own chance of this, stated with the estimate: 85%; the middle value does not contradict the limit.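

For the compounds shown here, compound 3, like compound 1 and compound 2, is reported only as a limit of the assay and not as a number, and no step from compound 1 or compound 2 to compound 3 can be read. The compounds shown leave open how large either change is, 4-hydroxyphenyl in place of 3-hydroxyphenyl or furan-2-yl in place of thiophen-2-yl.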